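Quinolin-8-yl for Dimethylphenyl: Expected Tolerance of Compound 4

The source may hold more compounds than are shown below. What is called first, only, known or untested is meant among the compounds shown, and "the series" means these compounds.

Compound 1, `O=C(Nc1ncc(C(Oc2ccc3cc(Br)ccc3c2)c2ccc(Cl)cc2)s1)C1CC1`, in an ADME assay on HepG2 2.2.15 cells (Homo sapiens) for cytotoxicity (a lower number here means that less compound is tolerated, a higher number that more compound is tolerated), gives "not toxic" (no number reported).
Compound 2, `Cc1noc(C)c1C(=O)Nc1ncc(C(Oc2ccc3cc(Br)ccc3c2)c2ccc(Cl)cc2)s1`, in this assay gives "not toxic" (no number reported).
Compound 3, `Cc1ccc(C)c(S(=O)(=O)Nc2ncc(C(Oc3ccc4cc(Br)ccc4c3)c3ccc(Cl)cc3)s2)c1`, in this assay gives > 50000 nM.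

Three compounds sharing the same core have been examined, and none of them has shown harm to the cells at the concentrations tested. For compound 3 the reported value is a limit of the assay and not a number, so its exact position is not known; what can be said is that it sits at the top of what was measured, since (the limit of > 50000 nM in this assay, at which 1 of the 3 values shown sits). Compounds 1 and 2 carry no number at all, only the statement that they were not toxic.

The untested compound 4, `O=S(=O)(Nc1ncc(C(Oc2ccc3cc(Br)ccc3c2)c2ccc(Cl)cc2)s1)c1cccc2cccnc12`, differs from compound 3 in one place: quinolin-8-yl in place of 2,5-dimethylphenyl on a sulfonyl sulfur. Among the measured compounds shown here, because no step between two measured compounds with numbers exists here, there is nothing to gauge how such a change shifts the read-out in this assay. Given that every compound so far has been tolerated, the expectation for this change is no step beyond the usual scatter, in either direction. Compound 4 is therefore estimated at 60000 nM, with a range from 20000 nM to 200000 nM, which corresponds to an expected step that the limit leaves unreadable from compound 3 to compound 4.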

Compound 4, half-maximal cytotoxic concentration: > 50000 nM
Compound 4: no number, only a limit; the forecaster's own chance of this, stated with the estimate: 80%; the middle value is on the limit's open side.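

Among the compounds shown here, compound 3 and compound 4 both end at a limit of this assay and not at a number, so no step between them can be read: the limit of > 50000 nM in this assay, at which 2 of the 4 values shown sit.

The compounds shown leave open how much of each the cells would tolerate before harm appears, and whether quinolin-8-yl in place of 2,5-dimethylphenyl on a sulfonyl sulfur changes that at all.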